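The compounds below may be only part of what the source reports. "The series", "measured", "known", "first", "only" and "open" are said of these compounds alone.

Measured so far:
- compound 1 `CC(=O)N1CCc2c(c(-c3ccc(Br)cc3)nn2CC(O)CN2CCC(n3c(O)nc4ccccc43)CC2)C1` — 80 nM in an assay on isolated protein for inhibition of cathepsin S (Homo sapiens); a higher number here means a weaker inhibitor, a lower number a stronger inhibitor
- compound 2 `CC(=O)N1CCc2c(c(-c3ccc(Br)cc3)nn2CC(O)CN2CCC(n3c(O)nc4cc(Cl)c(Cl)cc43)CC2)C1` — 110 nM in this assay

Compound 2 holds the highest of the two numbers in this assay; its only neighbour is compound 1, and the step of a 1.4-fold higher number from compound 1 to compound 2 (0.14 log units; within the scatter) lies within the scatter, so the two compounds are not separated on the numbers shown.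

Compound 3 `CC(=O)N1CCc2c(c(-c3ccc(Br)cc3)nn2CC(O)CN2CCC(n3c(O)nc4cccc(C)c43)CC2)C1` is not yet measured. It differs from compound 2 in one place: 2-hydroxy-7-methyl-1H-benzimidazol-1-yl in place of 5,6-dichloro-2-hydroxy-1H-benzimidazol-1-yl on a saturated ring carbon. Within the data shown here, the only measured step that bears on a change at this saturated ring carbon is a 1.4-fold higher number from compound 1 to compound 2 (0.14 log units; within the scatter), which was within the scatter. No compound with a methyl on the benzimidazole ring has been measured, so the direction of the new step is not fixed by any shown pair. Since exchange of the substitution on this group moved the number no further than the scatter between compound 1 and compound 2, no step beyond the scatter is expected here either, with the range kept wide for the untested methyl.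

The estimate for compound 3 in this assay is 90 nM, between 40 nM and 220 nM, which means an expected step of a 1.2-fold lower number from compound 2 to compound 3 (0.09 log units; within the scatter).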

Compound 3, half-maximal inhibitory concentration: 210 nM
Compound 3: middle estimate off by 2.3-fold (0.37 log units), on the low side; measured number inside the range.
By their numbers in this assay, from the lowest: compounds 1, 2 and 3 (each within the scatter of the next, the first and the last beyond it).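

In this assay, methyl in place of hydrogen on an aromatic carbon of the 2-hydroxy-1H-benzimidazol-1-yl group gives a 2.6-fold higher number from compound 1 to compound 3 (0.42 log units; beyond the scatter). Among these compounds, this modest step is the first at this saturated ring carbon to lie beyond the scatter, so substitution on this group is not always without effect on the number. The exchange of 5,6-dichloro-2-hydroxy-1H-benzimidazol-1-yl for 2-hydroxy-7-methyl-1H-benzimidazol-1-yl gives a 1.9-fold higher number from compound 2 to compound 3 (0.28 log units; within the scatter), which leaves compound 3 unseparated from compound 2, while only compound 1 and compound 3 stand apart; no supporting measurement bears on what lies behind this small difference.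

With a single methyl compound in hand, the series leaves open whether the step belongs to the methyl itself or to the place it occupies on the group. It also leaves open how an ethyl, a methoxy group, a fluorine or an amine at that aromatic carbon would compare with the methyl in compound 3, and whether any of them would move the number further from that of compound 1.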